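The source may report more compounds than this note shows. Statements on the series, on what has been measured and on what is new or still open speak of the compounds shown alone.

Compound 1 `Cc1ccc(-c2c3c(nc(C)c2C(OC(C)(C)C)C(=O)O)CCN(S(C)(=O)=O)C3)cc1` gives > 40000 nM in an ADME assay on MT2 cells (Homo sapiens) for cytotoxicity, read by XTT assay, with a stated time of 4 days (a lower number here means that less compound is tolerated, a higher number that more compound is tolerated), which is a limit of the assay.
Compound 2 `Cc1ccc(-c2c3c(nc(C)c2C(OC(C)(C)C)C(=O)O)CCN(CCCC2CCCC2)C3)cc1` gives > 40000 nM in this assay, again a limit.
Compound 3 `Cc1ccc(CCCN2CCc3nc(C)c([C@H](OC(C)(C)C)C(=O)O)c(-c4cc(F)c5c(c4C)CCCO5)c3C2)cc1F` gives > 40000 nM in this assay, also a limit.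

Compound 3 thus stands at a limit only, without a number of its own, and the same holds for all three values shown: the limit of > 40000 nM in this assay, at which 3 of the 3 values shown sit. No ordering among them can be read. Compound 4 `Cc1nc2c(c(-c3cc(F)c4c(c3C)CCCO4)c1[C@H](OC(C)(C)C)C(=O)O)CN(CCCc1ccncc1)CC2` differs from compound 3 in one place: pyridin-4-yl in place of 3-fluoro-4-methylphenyl on a saturated chain carbon, three bonds along the chain from an amine nitrogen in a ring. For the measured compounds named here, the only measured step touching the chain on the amine nitrogen in a ring is a step that the two limits leave unreadable from compound 1 to compound 2, a step that two limits leave unreadable. On that basis no step beyond the scatter is expected, and the estimated step is a step that the limit leaves unreadable from compound 3 to compound 4. Compound 4 is expected to give about 50000 nM in this assay, within 25000 nM to 100000 nM, most likely again reported as a limit.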

Compound 4, half-maximal cytotoxic concentration: > 40000 nM
Compound 4: only a limit was reported; the forecaster's own chance of this, stated with the estimate: 85%; the middle value lies beyond the limit too.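

The step from compound 3 to compound 4 cannot be read, because both compounds sit at a limit: the limit of > 40000 nM in this assay, at which 4 of the 4 values shown sit.
The compounds shown leave open whether any change among them shifts the result in this assay at all, and how they would rank there.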